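A Larger Amine Substituent on the Cyclohexyl Side Chain

A few compounds are considered here, and "the series" means these few. Any claim that something is new, unique, unknown or untested is made for them only; others in the source may bear on it.

Compound 1, `CCOC(=O)[C@H]1CC[C@H](CNC(=O)c2ccc(Cc3cc4c(cc3C)C(C)(C)CCC4(C)C)o2)CC1`, gives 2730 nM in an assay on isolated protein for binding affinity to Gonadotropin-releasing hormone receptor (Rattus norvegicus); a higher number here means a weaker inhibitor, a lower number a stronger inhibitor.
Compound 2, `Cc1cc2c(cc1Cc1ccc(C(=O)NCc3ccc(CN)cc3)o1)C(C)(C)CCC2(C)C`, gives 280 nM in this assay.
Compound 3, `Cc1cc2c(cc1Cc1ccc(C(=O)NCC3CCC(CN)CC3)o1)C(C)(C)CCC2(C)C`, gives 730 nM in this assay.

All three share the same core and differ only in the group carried on the saturated chain carbon bound to the amide-type nitrogen. Compound 3 sits in the middle of the measured set: its number is the second highest of the three, with a 2.6-fold higher number from compound 2 to compound 3 (0.42 log units; beyond the scatter) separating it from compound 2 and a 3.7-fold lower number from compound 1 to compound 3 (0.57 log units; beyond the scatter) separating it from compound 1. Compound 4, `Cc1cc2c(cc1Cc1ccc(C(=O)NCC3CCC(CNCc4cc(O)nc(O)n4)CC3)o1)C(C)(C)CCC2(C)C`, keeps the cyclohexyl side chain of compound 3 and carries (2,6-dihydroxypyrimidin-4-yl)methyl in place of hydrogen on an amine nitrogen. Among the compounds with values here, none of the measured steps alters this amine in the same way; each of them swaps the whole group on the side chain, and the two that bring in an aminomethyl group, a 9.8-fold lower number from compound 1 to compound 2 (0.99 log units; beyond the scatter) and a 3.7-fold lower number from compound 1 to compound 3 (0.57 log units; beyond the scatter), are both modest. With the amine of compound 3 kept in place and only gaining a larger substituent, the step of a 1.5-fold lower number from compound 3 to compound 4 (0.16 log units; within the scatter) is expected to be small, without a clear direction beyond the scatter. Compound 4 is therefore estimated at 500 nM, in the range 150 nM to 2000 nM.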

Compound 4, inhibition constant: 865 nM
Compound 4: the middle estimate sits 1.7-fold (0.24 log units) below what was measured, within the range that was stated.
By their numbers in this assay, from the lowest: compound 2; then compounds 3 and 4 (each within the scatter of the next); then compound 1.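

In this assay, putting (2,6-dihydroxypyrimidin-4-yl)methyl in place of hydrogen on the amine nitrogen gives a 1.2-fold higher number from compound 3 to compound 4 (0.07 log units; within the scatter). Within the data shown here, the earlier steps each swapped the whole group on the side chain, whereas this one keeps the cyclohexyl side chain and alters only the amine nitrogen, so it is the first direct reading of this position. It shows that this nitrogen can carry a substituent as large as a whole aromatic ring with its methyl link, and that in this assay the two compounds cannot be told apart; nothing measured here explains why the added group leaves the number within the scatter.

One compound cannot show whether this tolerance extends to other groups on the same nitrogen, such as a small methyl, a benzyl without hydroxyl groups, or an acetyl that would turn the amine into an amide. As far as these compounds go, it also remains open whether the (2,6-dihydroxypyrimidin-4-yl)methyl group would behave the same way on the amine of compound 2, where the side chain carries a phenyl ring instead of the cyclohexyl ring.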